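Aryl methyl for methoxy on the methylated core

A few compounds are considered here, and "the series" means these few. Any claim that something is new, unique, unknown or untested is made for them only; others in the source may bear on it.

Measured in a functional assay on A549 cells (Homo sapiens) for antiproliferative activity, with a stated time of 5 days; on this read-out lower numbers stand for stronger inhibition and higher numbers for weaker inhibition:
compound 1 `COc1ccc(-n2nc(-c3ccc4ccccc4c3)nc2N2C(=O)COC23C=CC(=O)C=C3)cc1` gives 260 nM
compound 2 `Cc1ccc(-n2nc(-c3ccc4ccccc4c3)nc2N2C(=O)COC23C=CC(=O)C=C3)cc1` gives 110 nM
compound 3 `COc1ccc(-n2nc(-c3ccc4ccccc4c3)nc2N2C(=O)C(C)OC23C=CC(=O)C=C3)cc1` gives 860 nM

Compound 2 differs from compound 1 by methyl in place of methoxy on an aromatic carbon, a change that gave a 2.4-fold lower number from compound 1 to compound 2 (0.37 log units; beyond the scatter). Compound 3 differs from compound 1 by methyl in place of hydrogen on a saturated ring carbon, which gave a 3.3-fold higher number from compound 1 to compound 3 (0.52 log units; beyond the scatter), leaving compound 3 the highest number of the three.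

Compound 4 `Cc1ccc(-n2nc(-c3ccc4ccccc4c3)nc2N2C(=O)C(C)OC23C=CC(=O)C=C3)cc1` is not yet measured. It differs from compound 3 by methyl in place of methoxy on an aromatic carbon, the same change as from compound 1 to compound 2, at a place described in identical words. The step from compound 3 to compound 4 in this assay is expected to be about a 2.3-fold lower number from compound 3 to compound 4 (0.35 log units; beyond the scatter). Within the data shown here, this rests on compound 1 and compound 2 alone because a 2.4-fold lower number from compound 1 to compound 2 (0.37 log units; beyond the scatter) is the only measured instance of the change, so the range is kept wide. Compound 4 is estimated at 380 nM, between 200 nM and 800 nM.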

Compound 4, half-maximal inhibitory concentration: 1210 nM
The estimate for compound 4 lay 3.2-fold (0.50 log units) below the measured number; measured number above the stated range.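

In this assay, methyl in place of methoxy does not carry over unchanged from the core of compound 1 to the methylated core, where the step is a 1.4-fold higher number from compound 3 to compound 4 (0.15 log units; within the scatter), and the two steps differ: the same change on two cores in this assay, a 2.4-fold lower number (0.37 log units; beyond the scatter) from compound 1 to compound 2 and a 1.4-fold higher number (0.15 log units; within the scatter) from compound 3 to compound 4, 3.3-fold (0.52 log units) apart, beyond the scatter of two such steps. Methyl in place of hydrogen on the saturated ring carbon gives a larger step with the 4-methylphenyl group, an 11-fold higher number from compound 2 to compound 4 (1.04 log units; beyond the scatter), than with the 4-methoxyphenyl group: the same change on two cores in this assay, a 3.3-fold higher number (0.52 log units; beyond the scatter) from compound 1 to compound 3 and an 11-fold higher number (1.04 log units; beyond the scatter) from compound 2 to compound 4, 3.3-fold (0.52 log units) apart, beyond the scatter of two such steps. The two changes thus do not add up across these four compounds, but this is one pair of cores and does not show how either change behaves on any other core.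

Open, from the compounds shown here alone, is whether an amine or a chlorine in place of the methoxy would give steps that also depend on the core. Also open, going by these compounds, is how an ethyl or a longer chain on the saturated ring carbon would compare with the methyl.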